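A chloro step on compound 3 in growth inhibition

A few compounds are considered here, and "the series" means these few. Any claim that something is new, unique, unknown or untested is made for them only; others in the source may bear on it.

- compound 1 `COc1ccccc1/C=C/C(=O)c1c(O)cc2occc2c1OC` gives > 100000 nM as a limit
- compound 2 `COc1c(C(=O)/C=C/c2ccc(Cl)cc2)c(O)c(Br)c2occc12` gives 6720 nM as a value
- compound 3 `C=CCc1c(O)c(C(=O)/C=C/c2ccccc2)c(OC)c2ccoc12` gives 4410 nM as a value

Compound 1 gives > 100000 nM in a functional assay on A549 cells (Homo sapiens) for inhibition, with a stated time of 48 h (a lower number here means a stronger inhibitor of growth, a higher number a weaker inhibitor of growth), as a limit and not a number.

Compound 3 gives 4410 nM in this assay and stands within the scatter of compound 2, which gives 6720 nM in the same read-out.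

Compound 4 `C=CCc1c(O)c(C(=O)/C=C/c2ccc(Cl)cc2)c(OC)c2ccoc12` differs from compound 3 by chloro in place of hydrogen on an aromatic carbon and so turns phenyl to 4-chlorophenyl, para to a large group. Among the measured compounds shown here, no measured pair isolates this change. Compound 2 also carries 4-chlorophenyl, though it differs elsewhere, and gives 6720 nM in a range close to compound 3, so no step beyond the scatter is expected in this assay in either direction.

The expected 1.1-fold lower number from compound 3 to compound 4 (0.04 log units; within the scatter) stays within the scatter.

For compound 4 the estimated value is 4000 nM with an expected range from 1500 nM to 11000 nM in this estimate.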

Compound 4, concentration for 50% growth inhibition: 4700 nM
For compound 4 the middle estimate is 1.2-fold (0.07 log units) below the measured one; the range from low to high includes it.
By their numbers in this assay, from the lowest: compounds 3, 4 and 2 (each within the scatter of the next). At a limit, above all of these: compound 1.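

In this assay, among the compounds shown here, chloro in place of hydrogen on an aromatic carbon, turning phenyl to 4-chlorophenyl, gives a 1.1-fold higher number from compound 3 to compound 4 (0.03 log units; within the scatter), and this is the first measured pair to isolate that change. Allyl in place of bromo on an aromatic carbon gives a 1.4-fold lower number from compound 2 to compound 4 (0.16 log units; within the scatter), so neither single exchange separates these compounds in growth inhibition. Nothing measured here speaks to a cause for either step.

On these data alone, what an amine or a carboxylic acid would give in place of chloro at this position remains open. So does the effect of a longer chain in place of allyl.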